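Amino in place of ethoxy on a carbonyl carbon

The source may report more compounds than this note shows. Statements on the series, on what has been measured and on what is new or still open speak of the compounds shown alone.

In an ADME assay on HEK-293T cells (Homo sapiens) for cytotoxicity, read by luminescence, with a stated time of 24 h (on this read-out higher numbers stand for lower toxicity in this test and lower numbers for higher toxicity in this test), compound 1 (`COc1ccc(Cn2c(C(=O)NC(C)c3ccccc3)cc3sccc32)cc1`) gives > 100000 nM as a limit of the assay and not as a number. Compound 2 (`COc1ccc(Cn2c(C(=O)N3CCCCC3)cc3sccc32)cc1`) gives > 100000 nM as a limit too. Comparing the pair yields a step that the two limits leave unreadable from compound 1 to compound 2 and nothing further. Compound 3 (`CCOC(=O)C1CCN(C(=O)c2cc3sccc3n2Cc2ccc(OC)cc2)CC1`) gives 39000 nM and is the only one of the three with a true number. The picture so far rests on this single value and on the limit of > 100000 nM in this assay, at which 2 of the 3 values shown sit, alone.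

Compound 4 (`COc1ccc(Cn2c(C(=O)N3CCC(C(N)=O)CC3)cc3sccc32)cc1`) differs from compound 3 by amino in place of ethoxy on a carbonyl carbon with amino in place of ethoxy on a carbonyl carbon, which turns ethoxycarbonyl into carbamoyl. For the measured compounds named here, only one measured step touches this group, and it is the only one of readable size: placing ethoxycarbonyl on a saturated ring carbon gave an at least 2.5-fold lower number from compound 2 to compound 3 (0.40 log units; beyond the scatter) and so sets the scale. Compound 4 keeps the carbonyl but loses the ethoxy, so part of that step is expected to be undone. The expected move is a 1.9-fold higher number from compound 3 to compound 4 (0.28 log units; within the scatter) toward a higher number in this assay and a report as a limit is quite possible. Compound 4 is estimated at 75000 nM (expected range 30000 nM to 180000 nM).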

Compound 4, half-maximal cytotoxic concentration: > 100000 nM
Compound 4: only a limit was reported; the forecaster's own chance of this, stated with the estimate: 55%; middle value at least 1.3-fold (0.12 log units) away from the limit.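

In this assay, exchanging only the ethoxy for amino on the carbonyl carbon gives an at least 2.5-fold higher number from compound 3 to compound 4 (0.40 log units; beyond the scatter), so among these compounds a carbonyl on the saturated ring carbon is not enough to bring the number down, and the lower number of compound 3 goes with the ethoxycarbonyl group as a whole. This change runs in the opposite direction to the one that brought ethoxycarbonyl in, an at least 2.5-fold lower number from compound 2 to compound 3 (0.40 log units; beyond the scatter), and each of the two steps gives only a minimum size, as one end of each is a limit of the assay and not a number. The steps from compound 1 and from compound 2 to compound 4 cannot be read: each joins two limits.

Going by these compounds, whether the lower number needs the ethoxy itself stays open, and a methyl ester, a carboxylic acid or a longer alkoxy chain on the same carbonyl carbon would bear on that. How far compound 1, compound 2 and compound 4 lie from one another also stays open, as all three stop at the same point: the limit of > 100000 nM in this assay, at which 3 of the 4 values shown sit.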